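The source may hold more compounds than are shown below. What is called first, only, known or untested is meant among the compounds shown, and "the series" means these compounds.

Measured compounds:
compound 1 `CS(=O)(=O)c1ccccc1Nc1nc2c(Nc3ccc(C(F)(F)F)cc3)ncnc2s1` — 221 nM
compound 2 `CSc1nc(Nc2ccc(C(F)(F)F)c(Cl)c2)c2nc(Nc3c(Cl)cccc3Cl)sc2n1` — 113 nM
compound 3 `CN(C)c1nc(Nc2ccc(C(F)(F)F)cc2)c2nc(Nc3c(Cl)cccc3Cl)sc2n1` — 43 nM

In a functional assay on HEK293 cells for antagonist activity at transient receptor potential cation channel subfamily V member 1 (Rattus norvegicus), read by calcium flux (on this read-out lower numbers stand for stronger inhibition and higher numbers for weaker inhibition), compound 1 gives 221 nM, the highest number of the three. Compound 2 sits closest, and its 113 nM lies within the usual scatter of that of compound 1, so no order between the two can be read. Compound 3 is furthest off, and its 43 nM lies beyond the scatter, so compound 3 inhibits more strongly than compound 1. Going by the values given here, no pair among the measured compounds differs in one place only, so no single-change step is available to calibrate the change under study.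

Compound 4 `OCc1cc(Cl)c(Nc2nc3c(Nc4ccc(C(F)(F)F)cc4)ncnc3s2)c(Cl)c1` is not yet measured. It differs from compound 1 by 2,6-dichloro-4-(hydroxymethyl)phenyl in place of 2-(methylsulfonyl)phenyl on a nitrogen on an aromatic ring. Compounds 2 and 3 each differ from compound 1 at more than one place, so their numbers give only loose guidance. Since compound 3 reaches 43 nM and compound 2 reaches 113 nM in this assay, a step toward a lower number for compound 4 is expected, of modest size and not certainly beyond the scatter, as a 2.5-fold lower number from compound 1 to compound 4 (0.39 log units; beyond the scatter). Compound 4 is therefore estimated at 90 nM, within a range from 30 nM to 270 nM.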

Compound 4, half-maximal inhibitory concentration: 0.5 nM
For compound 4 the middle estimate is 180-fold (2.26 log units) above the measured one; the measured number lies below the stated range.
By their numbers in this assay, from the lowest: compound 4; then compound 3; then compounds 2 and 1 (each within the scatter of the next).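

In this assay, the group on a nitrogen on an aromatic ring proves to be a position of very large effect: with the rest of the core of compound 1 unchanged, 2,6-dichloro-4-(hydroxymethyl)phenyl in place of 2-(methylsulfonyl)phenyl gives a 440-fold lower number from compound 1 to compound 4 (2.65 log units; beyond the scatter) and the step lies far beyond the scatter. The earlier compounds shown here could not show this, since no two of them differed in one place only, and this step is the only measured size of any single change. Both groups keep the same six-membered aromatic ring of carbon only and the same heavy-atom count, so the step comes from the substituents on that ring, but nothing available explains why it is so large.

The step changes several substituents at once, so the two chlorines and the hydroxymethyl cannot be told apart: a plain 2,6-dichlorophenyl group, or a 2,6-dichlorophenyl group with a carboxylic acid or an aminomethyl group in place of the hydroxymethyl, would divide it. Going by these compounds, whether the same change holds on a core carrying the methylthio or dimethylamino group of compound 2 and compound 3 also stays open.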